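A few compounds are considered here, and "the series" means these few. Any claim that something is new, unique, unknown or untested is made for them only; others in the source may bear on it.

Measured compounds:
compound 1 `O=C(Nc1cccc(-c2oc3cc(-c4ccc(F)cc4)ccc3c(=O)c2O)c1)c1ccc(F)cc1F` — 13500 nM
compound 2 `Cc1cccc(C(=O)Nc2cccc(-c3oc4cc(-c5ccc(F)cc5)ccc4c(=O)c3O)c2)c1` — 7850 nM

For the measured compounds named here, compound 2 holds the lowest of the two numbers so far in a functional assay on MCF7 cells (Homo sapiens) for antiproliferative activity, read by CCK-8 assay, with a stated time of 72 h (on this read-out higher numbers stand for weaker inhibition and lower numbers for stronger inhibition), its nearest neighbour being compound 1, and the step of a 1.7-fold lower number from compound 1 to compound 2 (0.24 log units; within the scatter) lies within the scatter. Compound 3 `COc1cc(OC)cc(C(=O)Nc2cccc(-c3oc4cc(-c5ccc(F)cc5)ccc4c(=O)c3O)c2)c1` has not yet been measured; it differs from compound 2 by 3,5-dimethoxyphenyl in place of 3-methylphenyl on a carbonyl carbon. Going by the values given here, the only measured step that bears on this position is the exchange of the aryl group on the same carbonyl carbon, a 1.7-fold lower number from compound 1 to compound 2 (0.24 log units; within the scatter), which did not move the number beyond the scatter. Among the compounds with values here, with one such step as the sole guide, no clear direction can be drawn, and a change of a similar, modest size is expected in this assay. For compound 3 the expected value is therefore 8000 nM, with a range from 3000 nM to 22000 nM, which means an expected step of a 1.0-fold higher number from compound 2 to compound 3 (0.01 log units; within the scatter) that stays near the scatter.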

Compound 3, half-maximal inhibitory concentration: 3470 nM
Compound 3: the middle estimate sits 2.3-fold (0.36 log units) above what was measured; low and high end bracket the measured number.
By their numbers in this assay, from the lowest: compound 3; then compounds 2 and 1 (each within the scatter of the next).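

In this assay, the aryl group on the carbonyl carbon whose other neighbour is the amide-type nitrogen now moves the number beyond the scatter, which the earlier exchange at this place had not done: 3,5-dimethoxyphenyl gives a 2.3-fold lower number from compound 2 to compound 3 (0.35 log units; beyond the scatter) and a 3.9-fold lower number from compound 1 to compound 3 (0.59 log units; beyond the scatter) against the two earlier groups. Both steps are modest, but they show that this position is not indifferent to the group it carries, and compound 3 holds the lowest number of the three. Nothing at hand explains why this exchange lowers the number.

The compounds shown leave open whether a single methoxy group would give the same step, or whether both are needed. They also leave open how this position would respond to an amine or a carboxylic acid on the aryl ring.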